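Replacing piperidinyl with an arylamine on a shared core

The source may hold more compounds than are shown below. What is called first, only, known or untested is meant among the compounds shown, and "the series" means these compounds.

Measured compounds:
Compound 1, `CCCCCCNc1nc(SCc2ccc(C(F)(F)F)cc2)nc2ccccc12`: in a functional assay on MGC-803 cells (Homo sapiens) for cytotoxicity, read by MTT assay, with a stated time of 72 h (on this read-out higher numbers stand for weaker inhibition and lower numbers for stronger inhibition), compound 1 gives 13100 nM.
Compound 2, `CCCCCCCCCCCCCCNc1nc(SCc2ccc(C(F)(F)F)cc2)nc2ccccc12`: compound 2 reaches only a limit of the assay, > 50000 nM.
Compound 3, `FC(F)(F)c1ccc(CSc2nc(N3CCCCC3)c3ccccc3n2)cc1`: compound 3 gives 18600 nM.

Compound 3 and compound 1 sit close together, separated by a 1.4-fold higher number from compound 1 to compound 3 (0.15 log units; within the scatter), a gap within the scatter, so neither can be called the stronger. The only clearly larger move among the measured compounds is an at least 3.8-fold higher number from compound 1 to compound 2 (0.58 log units; beyond the scatter), where the longer chain pushed the number out to the assay's ceiling (the limit of > 50000 nM in this assay, at which 1 of the 3 values shown sits).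

Compound 4, `FC(F)(F)c1ccc(CSc2nc(Nc3ccccc3C(F)(F)F)c3ccccc3n2)cc1`, differs from compound 3 by (2-(trifluoromethyl)phenyl)amino in place of piperidin-1-yl on an aromatic carbon. Within the data shown here, no measured step covers this exact change. The closest guide is the swap between compound 1 and compound 3, a 1.4-fold higher number from compound 1 to compound 3 (0.15 log units; within the scatter), which changed little; the chain lengthening in an at least 3.8-fold higher number from compound 1 to compound 2 (0.58 log units; beyond the scatter) involved a different kind of group and offers no direct parallel. The expected step is therefore small, a 1.6-fold lower number from compound 3 to compound 4 (0.19 log units; within the scatter), with no confident direction. Compound 4 is estimated at 12000 nM, likely falling between 4000 nM and 40000 nM.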

Compound 4, half-maximal inhibitory concentration: > 50000 nM
Compound 4: only a limit was reported; the forecaster's own chance of this, stated with the estimate: 15%; middle value at least 4.1-fold (0.61 log units) from the limit.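

At this position on the shared core, hexylamino and piperidin-1-yl could not be told apart, but in this assay (2-(trifluoromethyl)phenyl)amino in place of piperidin-1-yl gives an at least 2.6-fold higher number from compound 3 to compound 4 (0.42 log units; beyond the scatter), so the position does respond to the group it carries. The comparison with the hexyl compound points the same way, with 2-(trifluoromethyl)phenyl in place of hexyl on the nitrogen giving an at least 3.8-fold higher number from compound 1 to compound 4 (0.58 log units; beyond the scatter). Compound 4 gives only a limit of the assay, and a second, quite different change now ends there too: the limit of > 50000 nM in this assay, at which 2 of the 4 values shown sit.

As far as these compounds go, how far compound 4 lies past that limit stays unknown, so its steps have a lower bound on their size and no upper one. The compounds shown also cannot separate the aromatic ring from its trifluoromethyl group, a question that a plain phenylamino group at this position could address.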